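The source may hold more compounds than are shown below. What is called first, only, known or untested is meant among the compounds shown, and "the series" means these compounds.

Measured compounds:
- compound 1 `O=C(/C=C/c1ccc2c(c1)B(O)OC2)c1ccco1`: 20700 nM
- compound 2 `Cn1cccc1C(=O)/C=C/c1ccc2c(c1)B(O)OC2`: 93600 nM
- compound 3 `O=C(/C=C/c1ccc2c(c1)B(O)OC2)c1ccc(OCc2ccccc2)cc1`: 6000 nM

All three share the same core and the same enone linker, differing only in the group on the carbonyl carbon. In a functional assay on SK-OV-3 cells (Homo sapiens) for cytotoxicity, read by MTT assay, with a stated time of 48 h (on this read-out lower numbers stand for stronger inhibition and higher numbers for weaker inhibition), compound 1 gives 20700 nM, which is the second highest of the three numbers; compound 3 gives 6000 nM and compound 2 gives 93600 nM. For the measured compounds named here, the one single-point step in the set, a 4.5-fold higher number from compound 1 to compound 2 (0.66 log units; beyond the scatter), swaps the furan-2-yl on the carbonyl carbon for another five-membered heteroaryl and weakens inhibition modestly.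

Compound 4 `Nc1ccc(C(=O)/C=C/c2ccc3c(c2)B(O)OC3)cc1` is the next variation at that same position: 4-aminophenyl in place of furan-2-yl on a carbonyl carbon. The change brings in a six-membered ring of carbon only, as in compound 3, but with an amino group rather than the benzyloxy group of compound 3. The step from compound 1 to compound 2 bears on it only loosely, since it shows that the group on the carbonyl carbon moves the read-out beyond the scatter. Compound 3 shows that a six-membered carbon ring on that carbon goes with a lower number than compound 1. Going by the values given here, on that basis a lower number is expected for compound 4, with a step of about a 2.1-fold lower number from compound 1 to compound 4 (0.32 log units; beyond the scatter) in this assay, though the amino substituent has no direct precedent here, so the range is kept wide. Compound 4 is therefore estimated at 10000 nM, between 3000 nM and 30000 nM.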

Compound 4, half-maximal inhibitory concentration: 20200 nM
Beside the measured number, compound 4's estimate is 2.0-fold (0.31 log units) below it, and the stated range covers the measured number.
By their numbers in this assay, from the lowest: compound 3; then compounds 4 and 1 (each within the scatter of the next); then compound 2.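

In this assay, a six-membered ring of carbon only on the carbonyl carbon does not on its own set a compound apart from the furan-2-yl of compound 1: 4-aminophenyl in place of furan-2-yl gives a 1.0-fold lower number from compound 1 to compound 4 (0.01 log units; within the scatter). The substituent on that ring is what separates the two phenyl compounds, with amino in place of benzyloxy on an aromatic carbon giving a 3.4-fold higher number from compound 3 to compound 4 (0.53 log units; beyond the scatter), so the lower number of compound 3 goes with the benzyloxy-bearing ring and not with the ring alone. The 1-methyl-1H-pyrrol-2-yl group of compound 2 remains apart from both other small groups at this position, as 4-aminophenyl in its place gives a 4.6-fold lower number from compound 2 to compound 4 (0.67 log units; beyond the scatter).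

No measurement at hand gives a reason for any of these steps. Still open, on these data alone, is where a plain phenyl, a methoxy-bearing phenyl or a dimethylamino-bearing phenyl would fall relative to compound 3 and compound 4, and whether a longer chain than benzyloxy on the ring would lower the number further.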